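Replacing a Pyrrolidine Side Group with a Phenyl Oxazolidinone

A few compounds are considered here, and "the series" means these few. Any claim that something is new, unique, unknown or untested is made for them only; others in the source may bear on it.

Measured compounds:
- compound 1 `COC1CCN(CC(=O)N2CCN(c3sc(C(F)(F)F)nc3-c3nc4ccccc4[nH]3)C[C@H]2C)C1`: 42 nM
- compound 2 `Cc1nc(C)n(CC(=O)N2CCN(c3sc(C(F)(F)F)nc3-c3nc4c(F)cccc4[nH]3)C[C@H]2C)n1`: 3.1 nM

Among the compounds with values here, in a functional assay on CHO-K1 cells for antagonist activity at C-X-C chemokine receptor type 3 (Homo sapiens), read by FLIPR, with a stated time of 10 min, in the presence of a further agent that is not named here (a lower number here means a stronger inhibitor, a higher number a weaker inhibitor), compound 1 gives the higher of the two numbers measured so far, so it is the weaker inhibitor of the pair. Within the data shown here, compound 2 differs from compound 1 in more than one place, so no single structural step can be drawn between them; their two values simply show that compound 2 is the stronger inhibitor, with a gap that lies beyond the usual scatter.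

Compound 3 `C[C@@H]1CN(c2sc(C(F)(F)F)nc2-c2nc3ccccc3[nH]2)CCN1C(=O)CN1C(=O)OC[C@@H]1c1ccccc1` has not yet been measured. Its change from compound 1 is 2-oxo-4-phenyl-1,3-oxazolidin-3-yl in place of 3-methoxypyrrolidin-1-yl on a saturated chain carbon bound to a carbonyl carbon. Nothing measured here isolates the effect of this particular exchange, so the direction of the step cannot be read from the data. The estimate for compound 3 in this assay is 30 nM, expected to fall between 8 nM and 120 nM. This expected step, a 1.4-fold lower number from compound 1 to compound 3 (0.15 log units; within the scatter), is close to no change beyond the scatter, with wide uncertainty.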

Compound 3, half-maximal inhibitory concentration: 360 nM
For compound 3 the middle estimate is 12-fold (1.08 log units) below the measured one, outside the stated range (above it).
By their numbers in this assay, from the lowest: compound 2; then compound 1; then compound 3.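

In this assay, the side group on a saturated chain carbon bound to a carbonyl carbon proves sensitive to change: putting 2-oxo-4-phenyl-1,3-oxazolidin-3-yl in place of 3-methoxypyrrolidin-1-yl gives an 8.6-fold higher number from compound 1 to compound 3 (0.93 log units; beyond the scatter) and so a weaker inhibitor on the same core. The two groups have the same counts of hydrogen-bond donors and acceptors and neither carries a net charge, so these counts do not separate them; the entering group instead has 12 heavy atoms against 7, an added six-membered aromatic ring, a double bond outside aromatic rings and a defined stereocentre. Nothing shown here gives a measured reason for the weaker inhibition.

As far as these compounds go, the exchange brings the oxazolidinone ring and the phenyl ring at once, so it remains open which of them, or the defined stereocentre, goes with the loss. A plain 2-oxo-1,3-oxazolidin-3-yl without the phenyl ring, or the opposite configuration of the phenyl-bearing carbon, would begin to separate these parts.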